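A few compounds are considered here, and "the series" means these few. Any claim that something is new, unique, unknown or untested is made for them only; others in the source may bear on it.

Measured so far in a functional assay on EOL1 cells (Homo sapiens) for inhibition, read by fluorescence, with a stated time of 72 h; on this read-out lower numbers stand for stronger inhibition of growth and higher numbers for weaker inhibition of growth:
Compound 1 `CC(C)CCn1cnc2c(Nc3ccc(Cl)cc3)nc(N[C@H]3CC[C@H](N)CC3)nc21` gives 90 nM
Compound 2 `COc1cc(Nc2nc(N[C@H]3CC[C@H](N)CC3)nc3c2ncn3CCC(C)C)cc(OC)c1` gives 140 nM
Compound 3 `CC(C)CCn1cnc2c(Nc3cccc(Cl)c3)nc(N[C@H]3CC[C@H](N)CC3)nc21` gives 60 nM

Compound 3 and compound 1 cannot be told apart, since the measured difference is a 1.5-fold lower number from compound 1 to compound 3 (0.18 log units; within the scatter) only. Compound 2 stands further off, with a 2.3-fold lower number from compound 2 to compound 3 (0.37 log units; beyond the scatter) as the result.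

Compound 4 `CC(C)CCn1cnc2c(Nc3ccccc3)nc(N[C@H]3CC[C@H](N)CC3)nc21` carries hydrogen in place of chloro on an aromatic carbon and is otherwise the same as compound 3. Among the measured compounds shown here, no measured compound has this bare ring, so there is no direct precedent. The nearest evidence is a 1.5-fold lower number from compound 1 to compound 3 (0.18 log units; within the scatter) for the chloro changing place, and a 1.6-fold higher number from compound 1 to compound 2 (0.19 log units; within the scatter) for the swap to 3,5-dimethoxyphenyl. Changes on this ring have therefore been small so far, and a small step is likely here too, probably not beyond the scatter and, if anything, towards a higher number.

The expected move is a 1.7-fold higher number from compound 3 to compound 4 (0.22 log units; within the scatter) by this estimate. Compound 4 is expected at 100 nM in this assay as an estimate, with a likely range from 45 nM to 220 nM by the same reckoning.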

Compound 4, concentration for 50% growth inhibition: 10 nM
Beside the measured number, compound 4's estimate is 10-fold (1.00 log units) above it, outside the stated range (below it).
By their numbers in this assay, from the lowest: compound 4; then compounds 3, 1 and 2 (each within the scatter of the next, the first and the last beyond it).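

In this assay, taking the chloro off the ring matters far more than moving it: the shift of the chloro gave only a 1.5-fold lower number from compound 1 to compound 3 (0.18 log units; within the scatter), whereas its removal gives a 6.0-fold lower number from compound 3 to compound 4 (0.78 log units; beyond the scatter) and a 9.0-fold lower number from compound 1 to compound 4 (0.95 log units; beyond the scatter). The unsubstituted phenyl also stands well apart from the 3,5-dimethoxyphenyl, with a 14-fold lower number from compound 2 to compound 4 (1.15 log units; beyond the scatter), so each of the three substituted rings shown gives a clearly higher number than the bare ring, with no exception among these compounds. Nothing available here explains why the bare ring gives the lowest number.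

As far as these compounds go, it remains open whether any group at all can sit on this ring without raising the number, as a single fluorine or a methyl at the same place would show. From the compounds shown here alone, it is also open whether the bare ring would give the same advantage with a different chain on the shared core.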